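A few compounds are considered here, and "the series" means these few. Any claim that something is new, unique, unknown or untested is made for them only; others in the source may bear on it.

Measured compounds:
- Compound 1 `CCOc1ccc(-n2c(S)nnc2CSc2nnc(-c3ccccc3)n2-c2ccccc2)cc1`: "not determined" (no result reported)
- Compound 2 `Sc1nnc(CSc2nnc(-c3ccccc3)n2-c2ccccc2)n1-c1ccc(Cl)cc1`: 50300 nM
- Compound 3 `Sc1nnc(Sc2nnc(-c3ccccc3)n2-c2ccccc2)n1-c1ccc(Cl)cc1`: 49700 nM

In a functional assay on MDA-MB-231 cells (Homo sapiens) for inhibition, read by MTT assay, with a stated time of 48 h (on this read-out higher numbers stand for weaker inhibition and lower numbers for stronger inhibition), compound 2 gives 50300 nM, and compound 3 gives 49700 nM; the two numbers lie within the usual scatter of each other, so nothing separates them. Compound 1 has no result in this assay, entered as "not determined" (no result reported). Compound 4 `Fc1ccc(-n2c(S)nnc2CSc2nnc(-c3ccccc3)n2-c2ccccc2)cc1` is still to be measured. It differs from compound 2 in one place: fluoro in place of chloro on an aromatic carbon. Within the data shown here, no measured pair shows this change here, so its effect is unknown. The expected step of a 1.2-fold higher number from compound 2 to compound 4 (0.08 log units; within the scatter) is small and not clearly beyond the scatter in either direction. Compound 4 is therefore estimated at 60000 nM, with a range from 25000 nM to 150000 nM.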

Compound 4, half-maximal inhibitory concentration: 26800 nM
Compound 4: middle estimate off by 2.2-fold (0.35 log units), on the high side; the measured number falls inside the stated range.
By their numbers in this assay, from the lowest: compounds 4, 3 and 2 (each within the scatter of the next).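

In this assay, among these compounds, putting fluoro in place of chloro on the aromatic ring gives a 1.9-fold lower number from compound 2 to compound 4 (0.27 log units; within the scatter), so the first comparison at this position cannot tell the two halogens apart. The position accepts either group with no change that stands clear of the scatter. No other measurement bears on this result.

On these data alone, it remains open whether an amine or a carboxylic acid at this position would give a number clear of the scatter. As far as these compounds go, it is also open whether the same halogen swap would read alike in the core of compound 3.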